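Changing the ring on a well-tolerated compound

The source may report more compounds than this note shows. Statements on the series, on what has been measured and on what is new or still open speak of the compounds shown alone.

Within the data shown here, in an ADME assay on MT4 cells (Homo sapiens) for cytotoxicity, read by MTT assay, with a stated time of 4 days (a higher number here means that more compound is tolerated, a lower number that less compound is tolerated), compound 3 `Cc1c(Cc2c(F)cccc2F)nc(N2CCCCC2C)[nH]c1=O` gives 75000 nM, the only true number so far. Compound 1 `CCN(C)c1nc(Cc2c(F)cccc2F)c(C)c(=O)[nH]1` gives > 85000 nM, which is a limit. Compound 2 `CCN(CC)c1nc(Cc2c(F)cccc2F)c(C)c(=O)[nH]1` gives > 81000 nM, also a limit. Compound 4 `Cc1c(Cc2c(F)cccc2F)nc(N2CCN(C)CC2)[nH]c1=O` has 4-methylpiperazin-1-yl in place of 2-methylpiperidin-1-yl on an aromatic carbon. Two measured steps changed the group at this same place, and both are only floors on the true size. From an at least 1.1-fold lower number from compound 1 to compound 3 (0.05 log units; that floor lies within the scatter) and an at least 1.0-fold lower number from compound 2 to compound 3 (0.03 log units; that floor lies within the scatter), no step beyond the scatter is expected in this assay. The expected step is a 1.1-fold higher number from compound 3 to compound 4 (0.03 log units; within the scatter). Compound 4 is estimated at 80000 nM, with an expected range of 40000 nM to 160000 nM.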

Compound 4, half-maximal cytotoxic concentration: > 75000 nM
Compound 4 was reported as a limit; the forecaster's own chance of this, stated with the estimate: 50%; the middle value does not contradict the limit.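

In this assay, putting 4-methylpiperazin-1-yl in place of 2-methylpiperidin-1-yl, which adds a second nitrogen to the ring, gives a number no lower from compound 3 to compound 4 (the limit leaves the size open). So this place on the shared core accepts a ring with a second nitrogen without any readable loss of tolerance, and the result for compound 4 is a limit, not a true number: the limit of > 75000 nM in this assay, at which 1 of the 4 values shown sits. The steps from compound 1 and compound 2 to compound 4 cannot be read, since both ends of each are limits.

Going by these compounds, how much compound 4 is truly tolerated stays open. So does whether morpholin-4-yl, with an oxygen in the ring, or a primary amine would be tolerated at this place.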